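Aryl swap on a cytotoxicity-limited benzamide series

The compounds below may be only part of what the source reports. "The series", "measured", "known", "first", "only" and "open" are said of these compounds alone.

Compound 1 `CCOC(=O)CCCCCOc1cccc(CN(C(=O)c2ccccc2)C(C)C)c1` gives a limit of > 26000 nM in an ADME assay on Raji cells (Homo sapiens) for cytotoxicity, read by CellTiter-Glo and resazurin assay, with a stated time of 72 h; on this read-out lower numbers stand for an effect already at smaller amounts and higher numbers for an effect only at larger amounts of compound. Compound 2 `CCOC(=O)CCCCCOc1cccc(CN(C(=O)c2ccc(-c3ccc(C(C)=O)s3)cc2)C(C)C)c1` likewise gives only a limit of > 26000 nM in this assay. The step that the two limits leave unreadable from compound 1 to compound 2 therefore cannot be read, as the limit of > 26000 nM in this assay, at which 2 of the 2 values shown sit, shows both values sitting at the same limit. Compound 3 `CCOC(=O)CCCCCOc1cccc(CN(C(=O)c2ccc(-c3cc(OC)cc(OC)c3)cc2)C(C)C)c1` differs from compound 2 by 3,5-dimethoxyphenyl in place of 5-acetylthiophen-2-yl on an aromatic carbon. Within the data shown here, no measured step bears on this change with a readable size. Compound 3 is expected to remain at the limit in this assay, with an estimated step that the limit leaves unreadable from compound 2 to compound 3. The estimate for compound 3 in this assay is 30000 nM, between 13000 nM and 70000 nM.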

Compound 3, half-maximal effective concentration: > 26000 nM
Compound 3: only a limit was reported; the forecaster's own chance of this, stated with the estimate: 85%; the middle value lies beyond the limit too.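

Compound 3 joins compound 1 and compound 2 at a limit, so no step among these three can be read in this assay: the limit of > 26000 nM in this assay, at which 3 of the 3 values shown sit.

The compounds shown leave open whether the aryl groups differ at all in this assay, as none gives a measurable value.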